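Swapping 4-bromobenzyl for 2-methylbenzyl on the shared core

A few compounds are considered here, and "the series" means these few. Any claim that something is new, unique, unknown or untested is made for them only; others in the source may bear on it.

Measured in a functional assay on HepG2 cells (Homo sapiens) for antiproliferative activity, read by MTT assay, with a stated time of 24 h; on this read-out lower numbers stand for stronger inhibition and higher numbers for weaker inhibition:
- compound 1 `COc1cccc(C(=O)Oc2ccc3c(=O)c(-c4cc(OC)c(OC)cc4OC)coc3c2)c1`: > 10000 nM (a limit of the assay)
- compound 2 `COc1cc(OC)c(-c2coc3cc(OCc4ccc(Br)cc4)ccc3c2=O)cc1OC`: 1050 nM

Within the data shown here, compound 2 holds the only actual number so far, since the other result is a limit. Compound 3 `COc1cc(OC)c(-c2coc3cc(OCc4ccccc4C)ccc3c2=O)cc1OC` has 2-methylphenyl in place of 4-bromophenyl on a saturated chain carbon bound to an oxygen on an aromatic ring.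

Among the measured compounds shown here, the one measured step, an at least 9.5-fold lower number from compound 1 to compound 2 (0.97 log units; beyond the scatter), exchanged a carbonyl-linked group for 4-bromobenzyl, so it bears only loosely on this swap between two benzyl groups. For the measured compounds named here, no large step in this assay is therefore expected, and the expected step, a 1.4-fold higher number from compound 2 to compound 3 (0.15 log units; within the scatter), stays within the usual scatter. For compound 3 the estimated value is 1500 nM, with an expected range of 500 nM to 5000 nM.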

Compound 3, half-maximal inhibitory concentration: 1860 nM
Compound 3: the middle estimate sits 1.2-fold (0.09 log units) below what was measured, and the stated range covers the measured number.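

In this assay, the swap gives a 1.8-fold higher number from compound 2 to compound 3 (0.25 log units; within the scatter), so at this place two differently substituted benzyl groups read alike, and 4-bromophenyl is not needed to keep a measurable value. A second benzyl group also improves on the carbonyl-linked group of compound 1, with an at least 5.3-fold lower number from compound 1 to compound 3 (0.73 log units; beyond the scatter). The true size of that step stays unknown because the result for compound 1 is a limit: the limit of > 10000 nM in this assay, at which 1 of the 3 values shown sits.

Still open, on these data alone, is how a benzyl ring carrying an amine or a carboxylic acid would read here. A longer chain in place of the benzyl group is open too.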